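A few compounds are considered here, and "the series" means these few. Any claim that something is new, unique, unknown or untested is made for them only; others in the source may bear on it.

Values in a functional assay on NCI-H1975 cells (Homo sapiens) for cytotoxicity, read by MTT assay, with a stated time of 72 h; a higher number here means a weaker inhibitor, a lower number a stronger inhibitor:
- compound 1 `CN1CCN(c2ccc(Nc3ncc4nc(Nc5cccc([N+](=O)[O-])c5)n(C5CCCC5)c4n3)cc2)CC1`: 980 nM
- compound 2 `C#Cc1cccc(Nc2nc3cnc(Nc4ccc(N5CCN(C)CC5)cc4)nc3n2C2CCCC2)c1`: 650 nM
- compound 3 `CN1CCN(c2ccc(Nc3ncc4nc(Nc5ccc(Br)cc5F)n(C5CCCC5)c4n3)cc2)CC1`: 1120 nM

These compounds have a shared core and differ only in the aromatic group on a nitrogen. Compound 3, at 1120 nM, cannot be separated from the other two. The measured steps to it are a 1.1-fold higher number from compound 1 to compound 3 (0.06 log units; within the scatter) and a 1.7-fold higher number from compound 2 to compound 3 (0.24 log units; within the scatter), and both lie within the scatter of repeated measurements.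

The next compound is compound 4 `CN1CCN(c2ccc(Nc3ncc4nc(Nc5cc(Cl)ccc5Cl)n(C5CCCC5)c4n3)cc2)CC1`, which has not yet been measured. It carries 2,5-dichlorophenyl in place of 4-bromo-2-fluorophenyl on a nitrogen on an aromatic ring.

The remaining measured step at this place, a 1.5-fold lower number from compound 1 to compound 2 (0.18 log units; within the scatter), also lies within the scatter. All three measured changes of this group therefore leave the read-out without a clear difference. Within the data shown here, none of the measured compounds carries a chlorine, however, so the evidence for this new group is indirect. Resting on a 1.1-fold higher number from compound 1 to compound 3 (0.06 log units; within the scatter) and a 1.7-fold higher number from compound 2 to compound 3 (0.24 log units; within the scatter), no step beyond the scatter is expected in this assay.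

The expected change is a 1.2-fold lower number from compound 3 to compound 4 (0.09 log units; within the scatter).

Compound 4 is estimated at 900 nM, with an expected range from 400 nM to 2000 nM.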

Compound 4, half-maximal inhibitory concentration: 2540 nM
Estimate against measurement, compound 4: 2.8-fold (0.45 log units) below; the whole stated range lies below it.
By their numbers in this assay, from the lowest: compounds 2, 1 and 3 (each within the scatter of the next); then compound 4.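

In this assay, among these compounds, this position shows a difference beyond the scatter for the first time: the change of aromatic group gives a 2.3-fold higher number from compound 3 to compound 4 (0.36 log units; beyond the scatter), whereas every step among the three earlier compounds stayed within the scatter. The same holds against the other two compounds, with a 3.9-fold higher number from compound 2 to compound 4 (0.59 log units; beyond the scatter) and a 2.6-fold higher number from compound 1 to compound 4 (0.41 log units; beyond the scatter), so compound 4 is the weakest of the four, though only modestly, and the group on this nitrogen cannot be exchanged freely even when, as with 4-bromo-2-fluorophenyl and 2,5-dichlorophenyl, both groups hold 8 heavy atoms and neither has a hydrogen-bond donor or acceptor. Nothing measured here explains the rise.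

The compounds shown leave open whether the rise needs both chlorines or would also appear with a single chlorine on the phenyl ring, since compound 4 is the only one that carries chlorine. They also leave open how a phenyl ring bearing an amine or a carboxylic acid would read in this assay, and whether any group here can bring the number clearly below that of compound 2 at 650 nM.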